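This account rests on a few compounds, and the source may have more. Where it says the series, first, only, none or still open, it means among the compounds named here.

Measured in an ADME assay for permeability, using PAMPA, with a stated time of 5 h; a higher number here means that the compound crosses the layer faster, a lower number that the compound crosses the layer more slowly:
compound 1, `CCCCc1cn(-c2ccc(NC(=O)Nc3cc(OC4CCCC4)ccc3C)cc2)nn1`, gives 1.96 10^-6 cm/s
compound 2, `CC(C)CC(=O)OCCc1cn(-c2ccc(NC(=O)Nc3ccccc3C(F)(F)F)cc2)nn1`, gives 4.24 10^-6 cm/s
compound 3, `CCOC(=O)CCc1cn(-c2ccc(NC(=O)Nc3ccccc3C(F)(F)F)cc2)nn1`, gives 1.56 10^-6 cm/s

Among these three numbers compound 1 stands second highest: compound 3 is its nearest neighbour, within the scatter, while compound 2 lies further off, beyond the scatter. Within the data shown here, the only step between compounds that differ in a single place is a 2.7-fold lower number from compound 2 to compound 3 (0.43 log units; beyond the scatter), and it concerns a change on the chain carried by the shared core, not the ring that carries the urea.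

Compound 4, `CCCCc1cn(-c2ccc(NC(=O)Nc3ccccc3C)cc2)nn1`, is not yet measured in this assay. It differs from compound 1 by hydrogen in place of cyclopentyloxy on an aromatic carbon. Among the measured compounds shown here, no measured step touches this position or this group, so nothing in the data points to a change in either direction beyond the scatter. The author therefore expects compound 4 to stay close to compound 1, with a 1.2-fold lower number from compound 1 to compound 4 (0.06 log units; within the scatter). The estimate for compound 4 is 1.7 10^-6 cm/s, with a range from 0.7 10^-6 cm/s to 3.8 10^-6 cm/s.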

Compound 4, apparent permeability: 2.86 10^-6 cm/s
For compound 4 the middle estimate is 1.7-fold (0.23 log units) below the measured one; measured number inside the range.
By their numbers in this assay, from the lowest: compounds 3, 1, 4 and 2 (each within the scatter of the next, the first and the last beyond it).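

In this assay, hydrogen in place of cyclopentyloxy on an aromatic carbon, meta to a large group and para to a methyl group, gives a 1.5-fold higher number from compound 1 to compound 4 (0.16 log units; within the scatter). Among these compounds, this is the first reading at this position: the cyclopentyloxy group, with its 6 heavy atoms, its five-membered non-aromatic ring of carbon only and its 1 hydrogen-bond acceptor, can go without the number moving beyond the scatter. Nothing on hand offers an explanation for this result.

The compounds shown leave open whether an amine, a methoxy group or a carboxylic acid on this aromatic carbon would also stay within the scatter of compound 1 and compound 4. They also leave open whether the same replacement would read alike on a compound carrying the ester chain of compound 2.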